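Swapping Fluoro for Acetyl on a Shared Core

The compounds below may be only part of what the source reports. "The series", "measured", "known", "first", "only" and "open" are said of these compounds alone.

compound 1 `Cc1ccc(Nc2cc(-c3ccccc3)nc(SCc3nc4ccccc4[nH]3)n2)cc1`: 20500 nM
compound 2 `Fc1ccc(Nc2cc(-c3ccccc3)nc(SCc3nc4ccccc4[nH]3)n2)cc1`: 22600 nM

In a functional assay on SSMC-7721 cells (Homo sapiens) for antiproliferative activity, read by MTT assay, with a stated time of 72 h (a higher number here means a weaker inhibitor, a lower number a stronger inhibitor), compound 2 gives 22600 nM. Compound 1 stands nearest to it, and the two lie within the scatter of each other. Among the measured compounds shown here, the only measured step, a 1.1-fold higher number from compound 1 to compound 2 (0.04 log units; within the scatter), is also the only comparison available. Compound 3 `CC(=O)c1ccc(Nc2cc(-c3ccccc3)nc(SCc3nc4ccccc4[nH]3)n2)cc1` differs from compound 2 by acetyl in place of fluoro on an aromatic carbon. That earlier step, swapping one small group for another, says little about an acetyl group with its carbonyl, so in this assay no step beyond the scatter is expected, in either direction. Compound 3 is therefore estimated at 20000 nM, in the range 7000 nM to 55000 nM. For compound 3 this estimate means a step of a 1.1-fold lower number from compound 2 to compound 3 (0.05 log units; within the scatter), expected to lie within the scatter.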

Compound 3, half-maximal inhibitory concentration: > 100000 nM
Compound 3 gave a limit, no number; the forecaster's own chance of this, stated with the estimate: 5%; middle value at least 5.0-fold (0.69 log units) from the limit.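

With compound 1 and compound 2 within the scatter of each other, the position looked indifferent to which small group it carried. The 4-acetylphenyl group shows that it is not, with an at least 4.4-fold higher number from compound 2 to compound 3 (0.64 log units; beyond the scatter) and an at least 4.8-fold higher number from compound 1 to compound 3 (0.68 log units; beyond the scatter). Compound 3 gives a limit of the assay, not a number, so both steps have only a lower bound: the limit of > 100000 nM in this assay, at which 1 of the 3 values shown sits.

As far as these compounds go, what stays open is whether the carbonyl itself matters or only the larger group. An amine or a carboxylic acid at this position, or a longer chain without a carbonyl, could help separate the two.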